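Swapping one ring atom on an inactive sulfone

The compounds below may be only part of what the source reports. "The series", "measured", "known", "first", "only" and "open" are said of these compounds alone.

The account centres on compound 1, `O=S(=O)(CC1=NCCS1)c1c(-c2ccc(Cl)cc2)noc1-c1ccc(Cl)cc1`, whose result in a functional assay, tested at 75 ug/mL (a lower number here means a weaker effect, a higher number a stronger effect of the compound at the concentration tested), is recorded as "not active" (no number reported), so no single number places it on the scale. Two other sulfones carrying the oxygen-bearing five-membered ring do give numbers: compound 2, `O=S(=O)(CC1=NCCO1)c1n[nH]cc1-c1ccccc1`, shows 55.6% in this assay, and compound 3, `COc1ccc(-c2nn(-c3ccccc3)c(-c3ccc(C)cc3)c2S(=O)(=O)CC2=NCCO2)cc1`, shows 68.7% in this assay. Their cores differ from that of compound 1, so the two values tell only that a sulfone of this general kind can register an effect.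

Compound 4, `O=S(=O)(CC1=NCCO1)c1c(-c2ccc(Cl)cc2)noc1-c1ccc(Cl)cc1`, keeps the core of compound 1 and changes only the group on the chain carbon bound to the sulfonyl sulfur: a group of 5 heavy atoms (3 carbon, 1 nitrogen, 1 oxygen; one five-membered non-aromatic ring with 2 hetero atoms) in place of a group of 5 heavy atoms (3 carbon, 1 nitrogen, 1 sulfur; one five-membered non-aromatic ring with 2 hetero atoms), on a saturated chain carbon bound to a sulfonyl sulfur. Going by the values given here, no step between measured compounds exists for this exchange. Since compound 1 registers no effect, the change is expected to move the read-out upward in this assay, by an amount beyond the scatter but modest. Compound 4 is therefore estimated at 25%, within 0% to 55%.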

Compound 4, a percentage reported as activity, at one concentration (the size of the read-out at that concentration, not a potency): "not active" (no number reported)
The entry for compound 4 holds no number, and the estimate cannot be compared.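

In this assay compound 4 is recorded as "not active" (no number reported), as is compound 1, so no step can be read between compound 1 and compound 4. Nothing at hand bears on this result. The compounds shown leave open whether this ring exchange would alter the read-out on a core that registers an effect, such as that of compound 2 or compound 3.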